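The source may hold more compounds than are shown below. What is called first, only, known or untested is meant among the compounds shown, and "the series" means these compounds.

Working notes on the series, the step from compound 1 to compound 4.

Compound 1 `COc1cc(-c2cc(C(=O)O)c3ccccc3n2)ccc1OCC(=O)Nc1ccccc1` is the parent anilide. In an ADME assay on HaCaT cells (Homo sapiens) for inhibition (on this read-out higher numbers stand for weaker inhibition and lower numbers for stronger inhibition), compound 1 gives > 300000 nM, which is a limit of the assay and not a number. Compound 2 `COc1cc(-c2cc(C(=O)O)c3ccccc3n2)ccc1OCC(=O)Nc1cccc(F)c1` gives 148000 nM in this assay. Compound 3 `COc1cc(-c2cc(C(=O)O)c3ccccc3n2)ccc1OCC(=O)Nc1ccc(F)cc1` gives 286000 nM in this assay. The two fluoro analogues show an at least 2.0-fold lower number from compound 1 to compound 2 (0.30 log units; that floor lies within the scatter) and an at least 1.0-fold lower number from compound 1 to compound 3 (0.02 log units; that floor lies within the scatter), and between themselves a 1.9-fold higher number from compound 2 to compound 3 (0.29 log units; within the scatter); none of these steps is resolved beyond the scatter, and the floors from compound 1 rest on (the limit of > 300000 nM in this assay, at which 1 of the 3 values shown sits).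

Compound 4 `COc1cc(-c2cc(C(=O)O)c3ccccc3n2)ccc1OCC(=O)Nc1ccccc1C(F)(F)F` carries the change (trifluoromethyl in place of hydrogen on an aromatic carbon), placed ortho to a large group. Among the measured compounds shown here, the steps that bear on it are the two fluoro substitutions from compound 1, each only a floor within the scatter, so no step beyond the scatter is expected in either direction. The expected step is an at least 1.3-fold lower number from compound 1 to compound 4 (0.13 log units; that floor lies within the scatter). For compound 4 the expected value in this assay is 220000 nM, with a range from 60000 nM to 700000 nM, and a sizeable chance that only a limit is returned.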

Compound 4, half-maximal inhibitory concentration: 102000 nM
Compound 4: middle estimate off by 2.2-fold (0.33 log units), on the high side; measured number inside the range.
By their numbers in this assay, from the lowest: compounds 4, 2 and 3 (each within the scatter of the next, the first and the last beyond it). At a limit, above all of these: compound 1.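

In this assay, trifluoromethyl on this aromatic carbon, ortho to a large group, gives a step beyond the scatter, which neither fluoro substitution on compound 1 gave: an at least 2.9-fold lower number from compound 1 to compound 4 (0.46 log units; beyond the scatter). That step is a floor and not a full size, as compound 1 has only a limit and not a number: the limit of > 300000 nM in this assay, at which 1 of the 4 values shown sits. Measured against the 4-fluorophenyl group the change also resolves, with a 2.8-fold lower number from compound 3 to compound 4 (0.45 log units; beyond the scatter), but against the 3-fluorophenyl group it does not, with a 1.5-fold lower number from compound 2 to compound 4 (0.16 log units; within the scatter), so compound 2 and compound 4 cannot be ordered.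

Open, from the compounds shown here alone, is whether a methyl or chloro group on the same aromatic carbon would give a step of this size, or whether the step needs trifluoromethyl itself. Going by these compounds, the true size of any step from compound 1 also stays open.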